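Swapping the sulfonamide substituent: a lipophilicity expectation

The source may report more compounds than this note shows. Statements on the series, on what has been measured and on what is new or still open speak of the compounds shown alone.

Measured so far:
Compound 1 `CCc1ccc(N(CC(C)C)S(=O)(=O)c2ccc3c(c2)C(OC2CCCCC2)CC(C2CCOCC2)O3)cc1` — 6.28
Compound 2 `CCc1ccc(N(CC(C)C)S(=O)(=O)c2ccc3c(c2)C(O)CC(C(C)C2CCOCC2)O3)cc1` — 5.04
Compound 3 `CCS(=O)(=O)c1ccc(CN(CC(C)C)S(=O)(=O)c2ccc3c(c2)C(O)CC(C2CCOCC2)O3)nc1` — 1.42

In a physicochemical assay for lipophilicity, at pH 7.4 (a higher number here means a more lipophilic compound, a lower number a more polar compound), compound 3 gives the lowest of the three numbers. Its nearest neighbour is compound 2, whose number lies higher by a margin beyond the scatter, and the furthest is compound 1, higher still and also beyond the scatter. Going by the values given here, the three compounds share a core and differ in more than one place, so no single step between them can be isolated.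

Compound 4 `CCc1ccc(N(CC(C)C)S(=O)(=O)c2ccc3c(c2)C(O)CC(C2CCOCC2)O3)cc1` has not yet been measured in this assay. It differs from compound 3 in one place: 4-ethylphenyl in place of (5-(ethylsulfonyl)pyridin-2-yl)methyl on a sulfonamide nitrogen. With the (5-(ethylsulfonyl)pyridin-2-yl)methyl group gone and 4-ethylphenyl in its place, compound 4 closely resembles compound 2, which also carries 4-ethylphenyl on the sulfonamide nitrogen and differs only by a methyl on the chain next to the core.

A large upward step is expected from compound 3 to compound 4, because compound 2 gives 5.04 in this assay. The expected step is a number 3.18 log units higher from compound 3 to compound 4 (beyond the scatter), far beyond the scatter. Compound 4 is estimated at 4.6, with a range from 4.1 to 5.1.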

Compound 4, distribution coefficient: 4.12
Beside the measured number, compound 4's estimate is 0.48 log units above it, and the stated range covers the measured number.
By their numbers in this assay, from the lowest: compound 3; then compound 4; then compound 2; then compound 1.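

In this assay, the sulfonamide nitrogen now has a single-place reading: 4-ethylphenyl in place of (5-(ethylsulfonyl)pyridin-2-yl)methyl gives a number 2.70 log units higher from compound 3 to compound 4 (beyond the scatter), so this substituent change alone accounts for a large step with the rest of the structure held constant. Compound 4 also makes two further changes readable on their own: oxan-4-yl in place of 1-(oxan-4-yl)ethyl on a saturated ring carbon gives a number 0.92 log units lower from compound 2 to compound 4 (beyond the scatter), and hydrogen in place of cyclohexyl on an oxygen on a saturated carbon gives a number 2.16 log units lower from compound 1 to compound 4 (beyond the scatter). Nothing at hand gives a reason for any of these steps.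

The step at the sulfonamide nitrogen replaces the whole substituent at once, so the compounds shown do not separate what the ethylsulfonyl group, the ring with its hetero atom and the carbon that links that ring to the nitrogen each contribute. They also leave open how this assay would respond to an amine or a carboxylic acid on the aromatic ring at that nitrogen, or to a short chain such as methyl in place of the hydrogen on the oxygen.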